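Paw edema inhibition: aryl variation at the saturated ring carbon

The source may hold more compounds than are shown below. What is called first, only, known or untested is meant among the compounds shown, and "the series" means these compounds.

compound 1, `CN1C[C@@H](c2ccc(F)cc2)[C@@]2(Cc3ccccc3C2=O)[C@@]12C(=O)Nc1ccccc12`: 21.8%
compound 2, `CN1C[C@@H](c2cccs2)[C@@]2(Cc3ccccc3C2=O)[C@@]12C(=O)Nc1ccccc12`: 20%
compound 3, `CN1C[C@@H](c2ccc(Cl)cc2)[C@@]2(Cc3ccccc3C2=O)[C@@]12C(=O)Nc1ccccc12`: not yet measured

In a functional assay on the whole organism (strain Wister albino) for inhibition, with Rattus norvegicus as the target, read by paw edema, with stated times of 1 h and 4 h, at a dose of 50 mg/kg by the intraperitoneal route (a higher number here means more inhibition at the dose given (going by the name of the read-out), a lower number less inhibition), compound 1 gives 21.8% and compound 2 gives 20%. Among the compounds with values here, the single step joining them, a number 1.8 percentage points lower from compound 1 to compound 2 (within the scatter), stays within the scatter, so compound 2 and compound 1 are not told apart on the numbers at hand; compound 2 has no other neighbour in this assay.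

Compound 3 differs from compound 2 by 4-chlorophenyl in place of thiophen-2-yl on a saturated ring carbon. Within the data shown here, the only measured step that bears on this change is a number 1.8 percentage points lower from compound 1 to compound 2 (within the scatter), which moved from a halogen-bearing six-membered carbon ring to thiophen-2-yl without leaving the scatter. The step to compound 3 runs the other way, from thiophen-2-yl back to a halogen-bearing six-membered carbon ring, with chlorine in place of the fluorine of compound 1. Among the measured compounds shown here, no measured step shows a swap of one halogen for another at this position.

On that basis the step expected for compound 3 is a number 2 percentage points higher from compound 2 to compound 3 (within the scatter), no change beyond the scatter. Compound 3 is estimated at 22%, in the range 12% to 32%.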

Compound 3, a percentage reported as inhibition, in the whole organism at one dose (the size of the read-out at that dose, not a potency): 15.6%
Beside the measured number, compound 3's estimate is 6.4 percentage points above it; measured number inside the range.
By their numbers in this assay, from the lowest: compounds 3, 2 and 1 (each within the scatter of the next).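

In this assay, 4-chlorophenyl in place of thiophen-2-yl gives a number 4.4 percentage points lower from compound 2 to compound 3 (within the scatter), so this change on the saturated ring carbon does not separate the two groups on the numbers at hand. The series now also holds its first measured halogen swap at this position: chloro in place of fluoro on the aromatic carbon gives a number 6.2 percentage points lower from compound 1 to compound 3 (within the scatter), so a change of halogen does not separate compound 3 from compound 1 either, and none of the three steps among these compounds leaves the scatter. No measurement at hand offers an explanation for these numbers.

Still open, on these data alone, is whether any group on this saturated ring carbon can move the read-out beyond the scatter, for instance a phenyl ring carrying an amine or a carboxylic acid in place of the halogen, or a plain alkyl chain in place of the aromatic ring. Also open, as far as these compounds go, is whether a longer chain in place of the methyl group on the ring nitrogen would separate compounds that these aryl changes leave together, and, as each number comes from a single dose, how these compounds compare in potency.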